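From 2,6-difluorophenyl to 2,3,4-trifluorophenyl

The compounds below may be only part of what the source reports. "The series", "measured", "known", "first", "only" and "open" are said of these compounds alone.

In a functional assay on Jurkat cells (Homo sapiens) (on this read-out higher numbers stand for weaker inhibition and lower numbers for stronger inhibition), compound 3 (`CC(C)[C@H](NC(=O)COc1cccc2ccccc12)C(=O)N[C@@H](CC(=O)O)C(=O)COc1c(F)cccc1F`) gives 2040 nM as the lowest of three numbers, against compound 1 (`CC(C)[C@H](NC(=O)COc1cccc2ccccc12)C(=O)N[C@@H](CC(=O)O)C(=O)COC(=O)c1c(Cl)cccc1Cl`) at 10600 nM and compound 2 (`CC(C)[C@H](NC(=O)COc1cccc2ccccc12)C(=O)N[C@@H](CC(=O)O)C(=O)COc1ccc(-c2ccccc2)cc1`) at 87900 nM so far. Compound 4 (`CC(C)[C@H](NC(=O)COc1cccc2ccccc12)C(=O)N[C@@H](CC(=O)O)C(=O)COc1ccc(F)c(F)c1F`) carries 2,3,4-trifluorophenyl in place of 2,6-difluorophenyl on an oxygen on a saturated carbon. For the measured compounds named here, two measured steps bear on this place: a 43-fold lower number from compound 2 to compound 3 (1.63 log units; beyond the scatter) (large) and a 5.2-fold lower number from compound 1 to compound 3 (0.72 log units; beyond the scatter) (modest). Both start from a very different group, so neither measures a change between two fluorinated phenyl groups. The estimated step is a 1.2-fold higher number from compound 3 to compound 4 (0.09 log units; within the scatter) (expected to stay within the scatter). The estimate for compound 4 is 2500 nM (expected range 800 nM to 8000 nM).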

Compound 4, half-maximal inhibitory concentration: 35800 nM
Compound 4: the middle estimate sits 14-fold (1.16 log units) below what was measured, and the stated range ends below it.
By their numbers in this assay, from the lowest: compound 3; then compound 1; then compound 4; then compound 2.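

Exchanging one fluorinated phenyl group for another on this oxygen is not a neutral change in this assay: the step is an 18-fold higher number from compound 3 to compound 4 (1.24 log units; beyond the scatter). Fluorinated phenyl alone therefore does not secure the low number of compound 3, since 2,3,4-trifluorophenyl sits among the groups of the weaker compounds, with a 2.5-fold lower number from compound 2 to compound 4 (0.39 log units; beyond the scatter) and a 3.4-fold higher number from compound 1 to compound 4 (0.53 log units; beyond the scatter). No measurement on hand accounts for this difference.

On these data alone, whether the low number depends on 2,6-difluorophenyl specifically stays open. Unsubstituted phenyl, 2,6-dichlorophenyl or 2-fluorophenyl on the same oxygen would test this.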